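A few compounds are considered here, and "the series" means these few. Any claim that something is new, unique, unknown or untested is made for them only; others in the source may bear on it.

In a functional assay on MDA-MB-231 cells (Homo sapiens) for inhibition, read by MTT assay and WST assay, with a stated time of 72 h, tested at 10 uM (a higher number here means more inhibition of growth at the concentration tested, a lower number less inhibition of growth), compound 1 `O=C(Nc1ccc(Oc2ccc(-c3nccs3)cc2)cc1)Nc1cccc(C(F)(F)F)c1` gives 64.1%. Compound 2 `O=C(Nc1ccc(Oc2ccc(-c3nccs3)cc2)cc1)Nc1cc(C(F)(F)F)ccc1Cl` carries an extra chloro group and gives 60.4%. The change from compound 2 to compound 1 is hydrogen in place of chloro on an aromatic carbon, and the step that went with it was a number 3.7 percentage points higher from compound 2 to compound 1 (within the scatter), a step too small to count as a real difference.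

Compound 3 `O=C(Nc1ccc(Cl)cc1)Nc1ccc(Oc2ccc(-c3ncc[nH]3)cc2)cc1` is built on a different core; how the two cores differ is not broken down here. In this assay compound 3 gives 47.6%, the lowest of the three numbers, and its gaps to compound 1 and compound 2 lie beyond the usual scatter.

Compound 4 `O=C(Nc1ccccc1)Nc1ccc(Oc2ccc(-c3ncc[nH]3)cc2)cc1` has not yet been measured. It differs from compound 3 by hydrogen in place of chloro on an aromatic carbon. Among the compounds with values here, this is the same kind of change as the one from compound 2 to compound 1, but not the same: there the chloro sat ortho to a large group and para to a trifluoromethyl group, here it sits para to a large group. Because a number 3.7 percentage points higher from compound 2 to compound 1 (within the scatter) was within the scatter, the step from compound 3 to compound 4 is expected to be a number 1.4 percentage points higher from compound 3 to compound 4 (within the scatter). Compound 4 is therefore estimated at 49%, somewhere between 36% and 62%.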

Compound 4, percent growth inhibition at one concentration: 11.4%
Compound 4: middle estimate off by 37.6 percentage points, on the high side; the whole stated range lies above it.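

In this assay, putting hydrogen in place of chloro on the 4-chlorophenyl group gave a number 36.2 percentage points lower from compound 3 to compound 4 (beyond the scatter). Within the data shown here, a step seen on one core therefore did not carry over to the other core, and the comparison rests on only one pair of compounds per core: the same change on two cores in this assay, a number 3.7 percentage points higher (within the scatter) from compound 2 to compound 1 and a number 36.2 percentage points lower (beyond the scatter) from compound 3 to compound 4, 39.9 percentage points apart, beyond the scatter of two such steps This does not show why the two steps differ, as the pairs differ not only in their cores but also in the surroundings of the chloro, which in compound 3 sits para to a large group while compound 2 also carries a trifluoromethyl group, and two pairs make no rule for the whole series.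

Left open is what other groups in that same place on compound 4, such as fluoro, methoxy or an amine, would give in this assay. Also open, going by these compounds, is how the same change would behave on the core of compound 1 with the chloro para to a large group and no trifluoromethyl group present.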